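Half-life notes on the chloromethyl replacement step

The compounds below may be only part of what the source reports. "The series", "measured", "known", "first", "only" and "open" are said of these compounds alone.

Measured compounds:
compound 1 `NS(=O)(=O)c1cc(-c2nnc(CCl)o2)c(Cl)cc1SCc1ccccc1`: 0.235 h
compound 2 `NS(=O)(=O)c1cc(-c2nnc(CN3CCN(c4ccc(Cl)cc4)CC3)o2)c(Cl)cc1SCc1ccccc1`: 0.455 h

Both numbers come from an ADME assay on microsomes from liver (Homo sapiens) for metabolic stability, read by LC-MS, using NADPH, tested at 5 uM; on this read-out lower numbers stand for a shorter-lived compound and higher numbers for a longer-lived compound. Compound 1 stands lowest of the two; in this assay compound 2 gives 0.455 h, but this pair lies within the usual scatter, so no order between compound 1 and compound 2 is claimed.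

Compound 3 `NS(=O)(=O)c1cc(-c2nnc(Cn3cc(-c4ccccc4)nn3)o2)c(Cl)cc1SCc1ccccc1` is not yet measured. Relative to compound 1 it carries 4-phenyl-1H-1,2,3-triazol-1-yl in place of chloro on a saturated chain carbon bound to an aromatic carbon. Put another way, the chloromethyl of compound 1 becomes a (4-phenyl-1H-1,2,3-triazol-1-yl)methyl. Among the compounds with values here, no measured pair in this set differs in only one place, so there is no directly comparable step to lean on; the only guidance is that compound 2, which likewise replaces the chloro with a ring-bearing group on a saturated chain carbon bound to an aromatic carbon, gives 0.455 h in this assay, a number within the scatter of compound 1.

On that basis the step of a 1.5-fold higher number from compound 1 to compound 3 (0.17 log units; within the scatter) is expected to be small, if anything towards a longer-lived compound, and not clearly beyond the scatter. Compound 3 is estimated at 0.35 h in this assay, with a range from 0.15 h to 0.8 h.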

Compound 3, half-life: 0.21 h
For compound 3 the middle estimate is 1.7-fold (0.22 log units) above the measured one; the range from low to high includes it.
By their numbers in this assay, from the lowest: compounds 3, 1 and 2 (each within the scatter of the next, the first and the last beyond it).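

Within the data shown here, replacing chloro with 4-phenyl-1H-1,2,3-triazol-1-yl on a saturated chain carbon bound to an aromatic carbon gives a 1.1-fold lower number from compound 1 to compound 3 (0.05 log units; within the scatter) in this assay and is the first directly comparable step. It establishes no order between the two compounds, even though 11 heavy atoms enter in place of 1, with one five-membered aromatic ring with 3 hetero atoms, one six-membered aromatic ring of carbon only and 3 hydrogen-bond acceptors. No available measurement bears on why the read-out stays within the scatter across this change.

Among these compounds, it remains open whether any replacement at this position can move the half-life beyond the scatter, since this single step covers only one group, and a hydroxyl, a primary amine, a carboxylic acid or a longer chain could behave differently on the same carbon. From the compounds shown here alone, it is also open whether the triazole and its phenyl ring would each give the same result alone, which an unsubstituted 1H-1,2,3-triazol-1-yl group would help to separate.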